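The source may report more compounds than this note shows. Statements on the series, on what has been measured and on what is new or still open speak of the compounds shown alone.

Compound 1, `CC(Oc1ccccc1-c1cccnc1)C1=NCCN1`, gives 933 nM in an assay on CHO cells for displacement of a labelled ligand from Alpha-2B adrenergic receptor (Homo sapiens); on this read-out higher numbers stand for weaker inhibition and lower numbers for stronger inhibition.
Compound 2, `CC(Oc1ccccc1-c1ccccc1)C1=NCCO1`, gives 10000 nM in this assay.
Compound 3, `CC(Nc1ccccc1-c1ccccc1)C1=NCCN1`, gives 1150 nM in this assay.

Compound 1 has the lowest of the three numbers. Compound 3 sits so close to it that the two cannot be told apart within the scatter, while compound 2 stands well beyond the scatter with a much higher number. For the measured compounds named here, no pair of these three differs in a single place, so no measured step is available to anchor a prediction.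

Compound 4, `Cc1cccc(-c2ccccc2OC(C)C2=NCCN2)c1`, arises from compound 1 by a single change: 3-methylphenyl in place of pyridin-3-yl on an aromatic carbon. Compound 3, which also carries an all-carbon ring in that position though with a different link to the shared core, gives a number indistinguishable from compound 1, which suggests that the ring swap by itself need not move the result far. Compound 2 shows that larger shifts are possible, but it differs from compound 1 in more than one place.

Compound 4 is therefore expected to show a step of a 1.3-fold higher number from compound 1 to compound 4 (0.11 log units; within the scatter), one that is not confidently beyond the scatter in either direction. The estimate for compound 4 in this assay is 1200 nM, within a range from 400 nM to 4000 nM.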

Compound 4, inhibition constant: 537 nM
Estimate against measurement, compound 4: 2.2-fold (0.35 log units) above; the range from low to high includes it.
By their numbers in this assay, from the lowest: compounds 4, 1 and 3 (each within the scatter of the next, the first and the last beyond it); then compound 2.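

For the compounds shown here, the replacement of pyridin-3-yl by 3-methylphenyl gives the first step in this set that differs in one place, and in this assay it amounts to (a 1.7-fold lower number from compound 1 to compound 4 (0.24 log units; within the scatter)). At this aromatic carbon, ortho to a group of 8 heavy atoms, a ring of carbon only can therefore stand in place of the ring with 1 hetero atom without a step beyond the scatter, which compound 2 and compound 3 could not show, as each differs from compound 1 in more than one place. No measurement at hand accounts for this step.

The compounds shown leave open whether a carboxylic acid or an amine on this ring, or a longer chain in place of its methyl, would stay within the scatter of compound 1. Going by these compounds alone, they also leave open what the link to the shared core does alone, for no pair here changes only that.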